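The source may hold more compounds than are shown below. What is called first, only, known or untested is meant among the compounds shown, and "the series" means these compounds.

Measured in a functional assay on HepG2 cells (Homo sapiens) for inhibition, read by CCK-8 assay, with a stated time of 70 h; a higher number here means a weaker inhibitor, a lower number a stronger inhibitor
compound 1 (`Clc1ccc(COc2ccc(OCCOCCNC3CCCCC3)cc2)cc1`) 15100 nM
compound 2 (`c1ccc(COc2ccc(COc3ccc(OCCOCCNC4CCCCC4)cc3)cc2)cc1`) 18100 nM
compound 3 (`O=[N+]([O-])c1ccccc1COc1ccc(OCCOCCNC2CCCCC2)cc1`) 25500 nM

Compound 1 is separated from each of the other two compounds only by a step within the scatter, so it does not stand apart from them on these numbers.

Compound 4 (`COC(=O)c1ccc(COc2ccc(OCCOCCNC3CCCCC3)cc2)cc1`) has not yet been measured. It differs from compound 1 at one place (methoxycarbonyl in place of chloro on an aromatic carbon), with methoxycarbonyl in place of chloro on an aromatic carbon.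

Within the data shown here, two measured steps bear on this change. The closer one also replaces the chloro group, here with benzyloxy (a 1.2-fold higher number from compound 1 to compound 2 (0.08 log units; within the scatter)). The other replaces 4-chlorophenyl with 2-nitrophenyl (a 1.7-fold higher number from compound 1 to compound 3 (0.23 log units; within the scatter)). Among the measured compounds shown here, both stay within the scatter, although neither introduces methoxycarbonyl, and no measured compound carries that group. On this limited evidence, no step beyond the scatter is expected in this assay. The expected step is small (a 1.2-fold higher number from compound 1 to compound 4 (0.08 log units; within the scatter)). For compound 4 the estimated value is 18000 nM with an expected range (10000 nM to 32000 nM).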

Compound 4, half-maximal inhibitory concentration: 30300 nM
For compound 4 the middle estimate is 1.7-fold (0.23 log units) below the measured one; low and high end bracket the measured number.
By their numbers in this assay, from the lowest: compounds 1, 2, 3 and 4 (each within the scatter of the next).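

In this assay, the aromatic carbon para to a large group now carries methoxycarbonyl, with 4 heavy atoms and 2 hydrogen-bond acceptors, in place of chloro, with 1 heavy atom and none, and the result is a 2.0-fold higher number from compound 1 to compound 4 (0.30 log units; within the scatter). This group also stays within the scatter of the benzyloxy group at the same position, at a 1.7-fold higher number from compound 2 to compound 4 (0.22 log units; within the scatter), and the 4-(methoxycarbonyl)phenyl group does the same against the 2-nitrophenyl group, at a 1.2-fold higher number from compound 3 to compound 4 (0.07 log units; within the scatter), so all the exchanges read so far leave the four compounds unseparated. No measured information is available to explain this result.

Still open, going by these compounds, is whether a carboxylic acid or an amine on this aromatic carbon would give a step beyond the scatter from compound 1. Among these compounds, all four compounds keep the same amine end, so the series also leaves open whether a longer chain or another ring on that nitrogen in place of cyclohexyl would move the number in this cell assay, where the shared core has not yet been varied.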